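The source may report more compounds than this note shows. Statements on the series, on what has been measured and on what is new or still open speak of the compounds shown alone.

Compound 1 `Clc1ccc(C2ON=C(c3ccccc3Cl)O2)cc1Cl`: > 100000 nM
Compound 2 `CCC1(c2cccc(Cl)c2)ON=C(c2ccccc2Cl)O1`: > 100000 nM

Both measurements come from an ADME assay on HEK293 cells (Homo sapiens) for cytotoxicity, read by MTT assay, with a stated time of 44 h; a lower number here means a stronger inhibitor, a higher number a weaker inhibitor. In this assay compound 1 reports only a limit, > 100000 nM, and no number. Compound 2 likewise reports only a limit, > 100000 nM. Compound 2 therefore stands where every value shown stands, namely at the limit of > 100000 nM in this assay, at which 2 of the 2 values shown sit.

Compound 3 `Clc1cccc(C2ON=C(c3ccccc3Cl)O2)c1` differs from compound 2 in a single place: hydrogen in place of ethyl on a saturated ring carbon. Among the measured compounds shown here, no step between two measured compounds is available, so the size of this change cannot be read from a neighbouring pair. With both measured compounds sitting at the same limit, no step beyond the usual scatter is expected in this assay. Compound 3 is expected to give 100000 nM, with a range from 50000 nM to 300000 nM. That estimate means an expected step of a number no higher from compound 2 to compound 3 (the limit leaves the size open).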

Compound 3, half-maximal inhibitory concentration: > 100000 nM
Compound 3 was reported as a limit; the forecaster's own chance of this, stated with the estimate: 85%; the middle value sits exactly at the limit.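

In this assay compound 3 gives > 100000 nM and that is a limit, not a number. Among the compounds shown here, no step from compound 1 or compound 2 to compound 3 can be read, because all three sit at one limit: the limit of > 100000 nM in this assay, at which 3 of the 3 values shown sit. From the compounds shown here alone, whether hydrogen in place of ethyl or of chloro changes cytotoxicity at all stays open.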